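Phenyl in place of dimethylphenyl on the sulfonyl sulfur

The source may hold more compounds than are shown below. What is called first, only, known or untested is meant among the compounds shown, and "the series" means these compounds.

The measured compounds and their numbers in an assay on isolated protein for displacement of a labelled ligand from metabotropic glutamate receptor 5 (Homo sapiens), with a stated time of 60 min, tested at 1 uM; on this read-out lower numbers stand for less inhibition and higher numbers for more inhibition at the one concentration tested (going by the name of the read-out):
compound 1, `CC1CCN(c2c(S(=O)(=O)c3ccccc3)cnc3ccc(Cl)cc23)CC1`, 59%
compound 2, `Cc1ccc(S(=O)(=O)c2cnc3ccc(F)cc3c2N2CCC(C)CC2)cc1C`, 92%
compound 3, `Cc1cc(C)cc(S(=O)(=O)c2cnc3ccc(F)cc3c2N2CCC(C)CC2)c1`, 83%

On these three numbers compound 3 stands second; compound 2 lies within the scatter of it, while compound 1 lies beyond the scatter below it. For the measured compounds named here, the one measured step, a number 9 percentage points lower from compound 2 to compound 3 (within the scatter), moves the two methyl groups on the phenyl ring and changes nothing beyond the scatter.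

Compound 4, `CC1CCN(c2c(S(=O)(=O)c3ccccc3)cnc3ccc(F)cc23)CC1`, has not been measured in this assay. It differs from compound 3 in one place: phenyl in place of 3,5-dimethylphenyl on a sulfonyl sulfur. Going by the values given here, no measured step removes the methyl groups altogether, so the step from compound 2 to compound 3 speaks only indirectly. Compound 1 carries the same phenyl on the sulfonyl sulfur as compound 4, though its core differs in one further place, and in this assay compound 1 gives 59%, well under compound 3. Compound 4 is therefore expected to fall below compound 3, by a step of about a number 18 percentage points lower from compound 3 to compound 4 (beyond the scatter). The estimate for compound 4 is 65%, with a range from 45% to 85%.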

Compound 4, a percentage reported as inhibition, at one concentration (the size of the read-out at that concentration, not a potency): 40%
The estimate for compound 4 lay 25 percentage points above the measured number; the measured number lies below the stated range.
By their numbers in this assay, from the lowest: compound 4; then compound 1; then compounds 3 and 2 (each within the scatter of the next).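

In this assay the removal of both methyl groups is now measured directly: on the sulfonyl sulfur, phenyl in place of 3,5-dimethylphenyl gives a number 43 percentage points lower from compound 3 to compound 4 (beyond the scatter) and phenyl in place of 3,4-dimethylphenyl gives a number 52 percentage points lower from compound 2 to compound 4 (beyond the scatter) as the second large drop. Set against a number 9 percentage points lower from compound 2 to compound 3 (within the scatter) when the methyl groups only change place, this shows that in these compounds having the methyl groups counts for more than how they are arranged. The halogen on the core also matters when phenyl sits on the sulfur, since fluoro in place of chloro on an aromatic carbon gives a number 19 percentage points lower from compound 1 to compound 4 (beyond the scatter) as a modest step.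

As far as these compounds go, whether a single methyl group, or a methoxy group or a chloro group on the phenyl ring, would restore the number remains open, as does whether chloro in place of fluoro would matter with a dimethylphenyl group on the sulfur. No measurement at hand offers an explanation for any of these steps.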